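The source may report more compounds than this note shows. Statements on the series, on what has been measured and on what is new or still open speak of the compounds shown alone.

Working notes on the series. Compound 1 `NS(=O)(=O)c1cc(C(=O)Nc2ccc(C(F)(F)F)cc2)ccc1Cl` gives 2.76 in a physicochemical assay for lipophilicity (a higher number here means a more lipophilic compound, a lower number a more polar compound), the higher of the two numbers recorded so far; compound 2 `COc1ccccc1CNC(=O)c1ccc(Cl)c(S(N)(=O)=O)c1` gives 1.77 in this assay, a gap beyond the usual scatter. Compound 3 `CC(C)(C)OC(=O)c1ccc(NC(=O)c2ccc(Cl)c(S(N)(=O)=O)c2)cc1` has not yet been measured. It differs from compound 1 by tert-butoxycarbonyl in place of trifluoromethyl on an aromatic carbon. Going by the values given here, no measured pair in the set shows this change, so the step is judged from the structures alone: the expected step is a number 0.14 log units higher from compound 1 to compound 3 (within the scatter), small, slightly upward if anything, and plausibly within the scatter. Compound 3 is therefore expected to give about 2.9 in this assay, with a range from 2.4 to 3.4.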

Compound 3, partition coefficient: 1.83
The estimate for compound 3 lay 1.07 log units above the measured number; measured number below the stated range.
By their numbers in this assay, from the lowest: compounds 2 and 3 (each within the scatter of the next); then compound 1.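

At this position, on an aromatic carbon para to a large group, tert-butoxycarbonyl in place of trifluoromethyl gives, in this assay, a number 0.93 log units lower from compound 1 to compound 3 (beyond the scatter). Going by these compounds alone, this is the only single-place change read so far, and the larger entering group goes with the lower number, so group size alone does not set the direction here. No measurement on hand shows which feature of the entering group accounts for this step. Going by these compounds, whether a carboxylic acid, a methyl ester or an amine at this position would give a similar number remains open.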